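Adding one more fluoro to compound 1

The compounds below may be only part of what the source reports. "The series", "measured", "known", "first", "only" and "open" are said of these compounds alone.

Measured in a functional assay on NCI/ADR-RES cells (Homo sapiens) for cytotoxicity; on this read-out higher numbers stand for weaker inhibition of growth and lower numbers for stronger inhibition of growth:
- Compound 1 `COc1ccc(NS(=O)(=O)c2c(F)cc(F)c(F)c2F)cc1`: 4500 nM
- Compound 2 `COc1ccc(NS(=O)(=O)c2c(F)cc(F)cc2F)cc1`: > 50000 nM

Among the measured compounds shown here, compound 1, at 4500 nM, holds the only actual number so far. Compound 2 gives > 50000 nM, which is a limit of the assay and not a number.

Still unmeasured is compound 3 `COc1ccc(NS(=O)(=O)c2c(F)c(F)c(F)c(F)c2F)cc1`. It differs from compound 1 in one place: fluoro in place of hydrogen on an aromatic carbon. In words, this is fluoro in place of hydrogen on an aromatic carbon.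

For the measured compounds named here, only one measured step bears on this change. Removing a fluoro gave an at least 11-fold higher number from compound 1 to compound 2 (1.04 log units; beyond the scatter), a large loss of growth inhibition. From the compounds shown here alone, that step ends at the limit of > 50000 nM in this assay, at which 1 of the 2 values shown sits, so its true size stays open. Compound 3 makes the same kind of swap in the opposite direction, adding a fluoro rather than removing one. A single step is thin evidence, but it points towards a lower number in this assay, and a change beyond the scatter is expected. The expected change is a 15-fold lower number from compound 1 to compound 3 (1.18 log units; beyond the scatter). The estimated value for compound 3 is 300 nM, with an expected range from 60 nM to 1500 nM.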

Compound 3, concentration for 50% growth inhibition: 58 nM
Compound 3: middle estimate off by 5.2-fold (0.71 log units), on the high side; the whole stated range lies above it.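

In this assay, putting a fluoro on the one ring carbon that still carried a hydrogen in compound 1 gives a 78-fold lower number from compound 1 to compound 3 (1.89 log units; beyond the scatter), so this carbon, ortho to two fluoro groups and para to a fluoro group, strongly affects the read-out. Among the compounds shown here, the earlier step, an at least 11-fold higher number from compound 1 to compound 2 (1.04 log units; beyond the scatter), removed a fluoro from a different ring carbon, so this result is the first sign that a fluoro at this particular place matters, and none of the three compounds goes against the pattern that more fluoro groups on this ring come with stronger inhibition of growth. The new step also has real numbers at both ends, while the size of the earlier step stays open because it ends at a limit: the limit of > 50000 nM in this assay, at which 1 of the 3 values shown sits.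

What the compounds shown leave open is whether this position responds to fluoro alone, or whether a chloro, a methyl or a nitrile there would also lower the number. They also do not tell why the added fluoro has this effect, or whether it would hold if the methoxy group on the other side of the molecule were replaced by, for example, an amine.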